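Series notes: aryl swap on the double-bonded chain carbon

The source may hold more compounds than are shown below. What is called first, only, known or untested is meant among the compounds shown, and "the series" means these compounds.

Measured so far:
compound 1 `CCN(CC)CCCn1c(=O)/c(=C/c2cc(OC)c(OC)c(OC)c2)s/c1=C1\C(=O)Nc2ccc(Cl)cc21` gives 1650 nM in a functional assay on K562/Adr cells (Homo sapiens) for cytotoxicity, read by sulforhodamine B assay, with a stated time of 48 h; a higher number here means a weaker inhibitor, a lower number a stronger inhibitor
compound 2 `CCN(CC)CCCn1c(=O)/c(=C/c2cc(OC)c(OC)c(OC)c2)s/c1=C1/C(=O)Nc2ccc(Cl)cc21` gives 1650 nM in this assay
compound 3 `CCN(CC)CCCn1c(=O)/c(=C/c2cc(OC)c(OC)c(OC)c2)s/c1=C1/C(=O)Nc2ccc(C)cc21` gives 2020 nM in this assay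

Compound 2 stands level with compound 1 at the digits reported, the two together at the lowest numbers of the three; compound 3 sits a little higher, but within the scatter. The step of no change at the digits printed from compound 1 to compound 2 (within the scatter) is no change, which fits (the fact that compounds 1 and 2 differ only in the configuration as drawn). The step of a 1.2-fold higher number from compound 2 to compound 3 (0.09 log units; within the scatter) is also within the scatter, so neither measured step shows a shift that can be read as real.

Compound 4 `CCN(CC)CCCn1c(=O)/c(=C/c2ccc(O)cc2)s/c1=C1/C(=O)Nc2ccc(Cl)cc21` is the next one in this assay. Relative to compound 2 the change is 4-hydroxyphenyl in place of 3,4,5-trimethoxyphenyl on a double-bonded chain carbon bound to an aromatic carbon. Among the measured compounds shown here, no measured step touches this part of the molecule: the two steps known concern the configuration as drawn and the substituent on the aromatic carbon of the fused ring, and both are small. For the measured compounds named here, the expectation for compound 4 therefore rests on the narrow spread of the three known numbers and on the size of the change, which is larger than either measured one. A weaker result is expected for compound 4, with a wide range, the step being a 2.1-fold higher number from compound 2 to compound 4 (0.33 log units; beyond the scatter). Compound 4 is estimated at 3500 nM, between 1200 nM and 10000 nM.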

Compound 4, half-maximal inhibitory concentration: 48800 nM
For compound 4 the middle estimate is 14-fold (1.14 log units) below the measured one, outside the stated range (above it).
By their numbers in this assay, from the lowest: compounds 1, 2 and 3 (each within the scatter of the next); then compound 4.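

In this assay, among the compounds shown here, the change to 4-hydroxyphenyl in place of 3,4,5-trimethoxyphenyl gives a 30-fold higher number from compound 2 to compound 4 (1.47 log units; beyond the scatter) as the first step that lies beyond the scatter, so the group on the double-bonded chain carbon bound to an aromatic carbon is a place where a single change has a large effect. The narrow spread of compounds 1, 2 and 3 came from changes elsewhere in the molecule and gave no reading of this position. The swap alters several things at once, with 12 heavy atoms, 3 hydrogen-bond acceptors and 0 hydrogen-bond donors leaving and 7 heavy atoms, 1 hydrogen-bond acceptor and 1 hydrogen-bond donor entering, and nothing on hand accounts for the size of the step.

The compounds shown leave open whether the higher number follows from losing the methoxy groups or from gaining the hydroxyl, a question that 4-methoxyphenyl or unsubstituted phenyl on the same carbon would help to separate. Also open, as far as these compounds go, is whether the step holds with methyl in place of chloro, as in compound 3, since the aryl change is read from one pair only.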